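Ether substituent variation on the shared core of compound 1

The source may hold more compounds than are shown below. What is called first, only, known or untested is meant among the compounds shown, and "the series" means these compounds.

Three compounds share one core and differ only in the group on the ether oxygen. Compound 1 `C=CCOc1ccc2c(=O)c(-c3cc(OC)c(OC)cc3OC)coc2c1` gives 5900 nM in a functional assay on U-251 cells (Homo sapiens) for antiproliferative activity, read by MTT assay, with a stated time of 24 h; on this read-out higher numbers stand for weaker inhibition and lower numbers for stronger inhibition. Compound 2 `C#CCOc1ccc2c(=O)c(-c3cc(OC)c(OC)cc3OC)coc2c1` gives 6450 nM, and compound 3 `COc1ccc2c(=O)c(-c3cc(OC)c(OC)cc3OC)coc2c1` gives 9400 nM. Compound 1 has the lowest of the three numbers, but all three lie together: a 1.1-fold higher number from compound 1 to compound 2 (0.04 log units; within the scatter), a 1.6-fold higher number from compound 1 to compound 3 (0.20 log units; within the scatter) and a 1.5-fold higher number from compound 2 to compound 3 (0.16 log units; within the scatter) are each within the scatter, so vinyl, ethynyl and hydrogen on the saturated chain carbon bound to the ring oxygen cannot be told apart on these data.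

Compound 4 `COc1cc(OC)c(-c2coc3cc(OCc4ccccc4F)ccc3c2=O)cc1OC` takes the step from compound 1 in which (2-fluorophenyl in place of vinyl on a saturated chain carbon bound to an oxygen on an aromatic ring). Within the data shown here, none of the measured steps covers a group of this kind at that place; the three steps that do exist at that place all stay within the scatter, which gives no direction for a larger group. The working expectation for compound 4 is therefore a number close to that of compound 1, with the step of a 1.3-fold lower number from compound 1 to compound 4 (0.12 log units; within the scatter) taken as not beyond the scatter, and a wide range to reflect the absence of any comparable step. Compound 4 is estimated at 4500 nM, between 1300 nM and 15000 nM.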

Compound 4, half-maximal inhibitory concentration: 2890 nM
Compound 4: middle estimate off by 1.6-fold (0.19 log units), on the high side, within the range that was stated.
By their numbers in this assay, from the lowest: compound 4; then compounds 1, 2 and 3 (each within the scatter of the next).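

In this assay, the place on a saturated chain carbon bound to an oxygen on an aromatic ring now shows a response that vinyl, ethynyl and hydrogen did not show among themselves: 2-fluorophenyl gives steps beyond the scatter against all three (a 2.0-fold lower number from compound 1 to compound 4 (0.31 log units; beyond the scatter); a 2.2-fold lower number from compound 2 to compound 4 (0.35 log units; beyond the scatter); a 3.3-fold lower number from compound 3 to compound 4 (0.51 log units; beyond the scatter)), though each is modest. Compound 4, the only one of the four carrying an aromatic ring on that carbon, therefore stands apart, while compounds 1, 2 and 3 remain together, so the position is not indifferent to the group it carries. Nothing in the available data bears on the reason for this separation.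

Among these compounds, with only one aromatic group at this place, it stays open whether the lower number belongs to the phenyl ring or to the fluorine on it, a question that plain benzyl would address directly. Also open, on these data alone, is whether a longer chain ending in phenyl, or a chain ending in an amine or a carboxylic acid, would group with compound 4 or with compounds 1, 2 and 3.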